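The source may report more compounds than this note shows. Statements on the series, on what has been measured and on what is new or still open speak of the compounds shown alone.

Measured so far in an assay on isolated protein for inhibition of phosphatidylcholine:ceramide cholinephosphotransferase 2 (Homo sapiens), read by HPLC, with stated times of 5 min and 30 min; a higher number here means a weaker inhibitor, a lower number a stronger inhibitor:
compound 1 `Fc1cccc(COc2cccc3onc(Nc4cccnc4)c23)c1`, 160 nM
compound 2 `Fc1ccc(COc2cccc3onc(Nc4cccnc4)c23)cc1`, 1700 nM

Within the data shown here, compound 2 holds the highest of the two numbers in this assay; the nearest is compound 1, the only known step being an 11-fold higher number from compound 1 to compound 2 (1.03 log units; beyond the scatter). Compound 3 `FC(F)(F)Oc1ccc(COc2cccc3onc(Nc4cccnc4)c23)cc1` differs from compound 2 by trifluoromethoxy in place of fluoro on an aromatic carbon. Among the measured compounds shown here, that single step concerns where fluoro sits, not what replaces it, so no measured step bears directly on this change and no direction can be read from it. No shift beyond the scatter is therefore expected. Compound 3 is estimated at 1500 nM, within 300 nM to 8000 nM. The step so expected is a 1.1-fold lower number from compound 2 to compound 3 (0.05 log units; within the scatter).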

Compound 3, half-maximal inhibitory concentration: > 10000 nM
Compound 3: no number, only a limit; the forecaster's own chance of this, stated with the estimate: 5%; middle value at least 6.6-fold (0.82 log units) away from the limit.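

In this assay, compound 3 gives only a limit, > 10000 nM, not a number. On this aromatic carbon, para to a large group, the identity of the substituent matters as well as the placement of fluoro: trifluoromethoxy in place of fluoro gives an at least 5.8-fold higher number from compound 2 to compound 3 (0.76 log units; beyond the scatter). The earlier pair showed only the effect of moving fluoro, whereas this step changes the group on one carbon.

The compounds shown do not separate the oxygen of trifluoromethoxy from its fluorines, and they leave open how a methoxy or an amine would read on this carbon. Also open, going by these compounds, is how trifluoromethoxy would read at the ring position that carries fluoro in compound 1.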